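The source may hold more compounds than are shown below. What is called first, only, known or untested is meant among the compounds shown, and "the series" means these compounds.

In a physicochemical assay for solubility, read by spectrophotometry, in phosphate buffer, with a stated time of 2 h, at pH 7.4 (a lower number here means a less soluble compound, a higher number a more soluble compound), the three measured compounds stand as follows.
Compound 1 `COc1ccc2[nH]c(C(=O)N3CC(=O)N(Cc4ccccc4)[C@@H](COc4ccccc4)C3)cc2c1`: 12200 nM
Compound 2 `COc1ccc2[nH]c(C(=O)N3CC(=O)N(Cc4ccccc4)[C@@H](CCN4CCC5(CC4)CC5)C3)cc2c1`: > 25000 nM, a limit of the assay rather than a number
Compound 3 `COc1ccc2[nH]c(C(=O)N3CC(=O)N(Cc4ccccc4)[C@@H](COC(C)(C)C)C3)cc2c1`: 65500 nM

Compound 3 holds the highest of the two readable numbers. Its nearest neighbour is compound 1, and the gap between them, a 5.4-fold higher number from compound 1 to compound 3 (0.73 log units; beyond the scatter), lies beyond the usual scatter. The value of compound 2 is a limit of > 25000 nM in this assay, at which 1 of the 3 values shown sits, and cannot be ranked against compound 3.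

Compound 4 `COc1ccc2[nH]c(C(=O)N3CC(=O)N(Cc4ccccc4)[C@@H](CN4CCC(C(C)C)CC4)C3)cc2c1` differs from compound 3 in one place: 4-isopropylpiperidin-1-yl in place of tert-butoxy on a saturated chain carbon bound to a saturated ring carbon. Going by the values given here, two measured steps bear on an exchange of this kind. From compound 1 to compound 2, a saturated ring bearing a nitrogen entered in place of a phenoxy group, and the outcome was an at least 2.0-fold higher number from compound 1 to compound 2 (0.31 log units; beyond the scatter). The closer comparison, from compound 2 to compound 3, is a step that the limit leaves unreadable from compound 2 to compound 3 because compound 2 sits at the limit of > 25000 nM in this assay, at which 1 of the 3 values shown sits.

The evidence therefore does not fix the direction of the step in this assay. Among the compounds with values here, a nitrogen-bearing saturated ring did not lower the number in the one step that can be read, so for compound 4 a number close to that of compound 3 is expected, with the step of a 1.3-fold lower number from compound 3 to compound 4 (0.12 log units; within the scatter) estimated to stay within the scatter. The estimate for compound 4 in this assay is 50000 nM, in a range from 15000 nM to 160000 nM.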

Compound 4, solubility: 12000 nM
Estimate against measurement, compound 4: 4.2-fold (0.62 log units) above; measured number outside the range, below it.
By their numbers in this assay, from the lowest: compounds 4 and 1 (each within the scatter of the next); then compound 3.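

Going by these compounds alone, at this place on the shared core, a saturated ring bearing a nitrogen does not by itself keep the number high in this assay: exchanging tert-butoxy for 4-isopropylpiperidin-1-yl gives a 5.5-fold lower number from compound 3 to compound 4 (0.74 log units; beyond the scatter), the first readable step in which such a ring lowers the number. The same ring brings no readable change against phenoxy, with a 1.0-fold lower number from compound 1 to compound 4 (0.01 log units; within the scatter), so an aromatic group and this saturated ring cannot be told apart by their numbers here. The two nitrogen-bearing groups also differ from each other, with an at least 2.0-fold lower number from compound 2 to compound 4 (0.31 log units; beyond the scatter), so the nitrogen and the ring alone do not set the outcome, and this step starts from compound 2, whose value is a limit and not a number: the limit of > 25000 nM in this assay, at which 1 of the 4 values shown sits.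

As far as these compounds go, whether the lower number of compound 4 follows from the ring itself or from the isopropyl on it stays open, and a plain piperidin-1-yl or a morpholin-4-yl on this same carbon would separate the two. From the compounds shown here alone, how a carboxylic acid at this place would read in this assay also stays open.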